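Pyrrolidinyloxy in place of methyl on the benzamide ring

The source may report more compounds than this note shows. Statements on the series, on what has been measured and on what is new or still open speak of the compounds shown alone.

Within the data shown here, compound 2 `Cc1cc(-c2cccnc2)ccc1C(N)=O` holds the highest of the two numbers measured so far in an assay on cells for inhibition of MAP kinase-interacting serine/threonine-protein kinase 1 (Homo sapiens), read by mobility shift assay, with stated times of 10 min and 60 min, in the presence of a further agent that is not named here (a lower number here means a stronger inhibitor, a higher number a weaker inhibitor), where compound 2 gives 22000 nM. Among the measured compounds shown here, its only neighbour is compound 1 `CCOc1cc(-c2cccnc2)ccc1C(N)=O`, which in this assay gives 2200 nM. For the measured compounds named here, the single measured step, a 10-fold higher number from compound 1 to compound 2 (1.00 log units; beyond the scatter), exchanges the ethoxy of compound 1 for the methyl of compound 2.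

Compound 3 `NC(=O)c1ccc(-c2cccnc2)cc1OC1CCNC1` has not yet been measured. It differs from compound 2 by (pyrrolidin-3-yl)oxy in place of methyl on an aromatic carbon. Going by the values given here, an oxygen-linked substituent thus returns at the position carrying the ethoxy in compound 1, so the step of a 10-fold higher number from compound 1 to compound 2 (1.00 log units; beyond the scatter), read in reverse, is the one piece of evidence bearing on this change. Among the compounds with values here, the ring and the hydrogen-bond donor that enter with the new group have no counterpart among the measured compounds, and their effect cannot be judged from this series. On the evidence of the reverse of a 10-fold higher number from compound 1 to compound 2 (1.00 log units; beyond the scatter) the number is expected to fall, not rise, by a step beyond the scatter. Compound 3 is expected to give 1500 nM in this assay, with a range from 300 nM to 8000 nM. This corresponds to an expected step of a 15-fold lower number from compound 2 to compound 3 (1.17 log units; beyond the scatter).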

Compound 3, half-maximal inhibitory concentration: 1900 nM
Beside the measured number, compound 3's estimate is 1.3-fold (0.10 log units) below it, within the range that was stated.
By their numbers in this assay, from the lowest: compounds 3 and 1 (each within the scatter of the next); then compound 2.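

In this assay, (pyrrolidin-3-yl)oxy in place of methyl on this aromatic carbon, ortho to a carbamoyl group, gives a 12-fold lower number from compound 2 to compound 3 (1.06 log units; beyond the scatter) and so adds a second oxygen-linked group to the ethoxy of compound 1, each with a number well separated from that of the methyl compound, compound 2. The exchange on the oxygen gives a 1.2-fold lower number from compound 1 to compound 3 (0.06 log units; within the scatter) and leaves the two compounds indistinguishable in this assay, so the five-membered ring and the hydrogen-bond donor that enter with pyrrolidin-3-yl are accommodated here without a step beyond the scatter, and they bring no measurable gain over ethyl. No measurement at hand accounts for either step.

The series leaves open whether the ring nitrogen contributes anything at this position, a question that tetrahydrofuran-3-yloxy, with a ring oxygen in its place, or an open-chain 2-aminoethoxy group would address. It also leaves open whether the oxygen link itself is what separates these compounds from compound 2, which an aminomethyl group or a longer carbon chain on the same aromatic carbon would test.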